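This account rests on a few compounds, and the source may have more. Where it says the series, first, only, none or still open, it means among the compounds named here.

Measured so far:
- compound 1, `CN(Cc1ccc(OCCCN)cc1)c1nc2ccc(Oc3ccc(F)cc3)cc2s1`: 98000 nM
- compound 2, `CN(C)CCCOc1ccc(CN(C)c2nc3ccc(Oc4ccc(C(F)(F)F)cc4)cc3s2)cc1`: 46000 nM
- compound 3, `CN(C)CCCOc1ccc(CN(C)c2nc3ccc(Oc4ccc(C#N)cc4)cc3s2)cc1`: 69000 nM

All three were tested in an assay on SH-SY5Y cells for inhibition of Voltage-dependent N-type calcium channel subunit alpha-1B (Homo sapiens), read by FLIPR and calcium flux, with stated times of 600 s and 300 s, in the presence of a further agent that is not named here; on this read-out lower numbers stand for stronger inhibition and higher numbers for weaker inhibition. Compound 1 has the highest number of the three; its gap to compound 3 is within the scatter, while its gap to compound 2 is beyond it, so compound 2 is the only one of the three that can be said to inhibit more strongly than compound 1.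

Compound 4, `CN(Cc1ccc(OCCCN)cc1)c1nc2ccc(Oc3ccc(O)cc3)cc2s1`, has not yet been measured. It differs from compound 1 in one place: hydroxy in place of fluoro on an aromatic carbon. Going by the values given here, the only measured step that bears on this is the one on the same ring of compounds 2 and 3, a 1.5-fold higher number from compound 2 to compound 3 (0.18 log units; within the scatter), which swapped one group for another on that aromatic carbon without a change beyond the scatter. On that basis the step from compound 1 to compound 4 is expected to be small, with no clear direction, no change at the digits printed from compound 1 to compound 4 (within the scatter). The estimate for compound 4 in this assay is therefore 98000 nM, with a range from 45000 nM to 200000 nM.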

Compound 4, half-maximal inhibitory concentration: 117000 nM
Estimate against measurement, compound 4: 1.2-fold (0.08 log units) below; the range from low to high includes it.
By their numbers in this assay, from the lowest: compounds 2, 3, 1 and 4 (each within the scatter of the next, the first and the last beyond it).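

Replacing 4-fluorophenoxy with 4-hydroxyphenoxy gives a 1.2-fold higher number from compound 1 to compound 4 (0.08 log units; within the scatter) in this assay, even though hydroxy brings a hydrogen-bond donor and a hydrogen-bond acceptor and fluoro brings neither. Compounds 2 and 3 covered only an exchange between trifluoromethyl and cyano, and they carry a dimethylamino group at the end of the chain, so compounds 1 and 4 add a different kind of swap at this aromatic carbon on a different amine end. Neither swap moves the number beyond the scatter, so in these four compounds the read-out stays insensitive to what sits at this carbon.

Going by these compounds, whether a carboxylic acid, an amine or a longer chain at this carbon would shift the number beyond the scatter remains open. No measurement shown here accounts for the size of this step.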